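A few compounds are considered here, and "the series" means these few. Any claim that something is new, unique, unknown or untested is made for them only; others in the source may bear on it.

Measured so far:
- Compound 1 `Cc1nc(N2CCC(N3CCCC3)CC2)nc2ccc(NC(=O)C(C)Oc3ccc(Cl)cc3)cc12`: 401 nM
- Compound 2 `CCC1(O)CCN(c2nc(C)c3cc(NC(=O)COc4ccc(OC(F)(F)F)cc4)ccc3n2)CC1`: 59 nM

Both compounds were tested in a functional assay on CHO-K1 cells for antagonist activity at melanin-concentrating hormone receptor 1 (Homo sapiens), read by inositol phosphate accumulation; on this read-out higher numbers stand for weaker inhibition and lower numbers for stronger inhibition. Compound 2 gives the lowest number of the two values shown; compound 1, its nearest neighbour, gives a number that is higher by a gap that lies beyond the usual scatter of repeated measurements. Compound 1 and compound 2 differ in several places at once, so their two values say only how far apart they stand, not which part of the structure is responsible.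

Compound 3 `CCC1(O)CCN(c2nc(C)c3cc(NC(=O)COc4ccc(Cl)cc4)ccc3n2)CC1` has not yet been measured. It is built from compound 2 by one change: chloro in place of trifluoromethoxy on an aromatic carbon. The change sits on an aromatic carbon of a six-membered aromatic ring of carbon only, para to a large group.

For the measured compounds named here, no step between two measured compounds that differ in one place is available, so the size of the effect of this change is uncertain. A modest weakening, a 1.7-fold higher number from compound 2 to compound 3 (0.23 log units; within the scatter), is expected for compound 3, which is estimated to give 100 nM in this assay, with a plausible range from 35 nM to 300 nM.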

Compound 3, half-maximal inhibitory concentration: 384 nM
Beside the measured number, compound 3's estimate is 3.8-fold (0.58 log units) below it; the whole stated range lies below it.
By their numbers in this assay, from the lowest: compound 2; then compounds 3 and 1 (each within the scatter of the next).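

For the compounds shown here, this is the first comparison between two compounds that differ in one place: going from 4-(trifluoromethoxy)phenoxy to 4-chlorophenoxy, with the rest of the molecule unchanged, gives in this assay a 6.5-fold higher number from compound 2 to compound 3 (0.81 log units; beyond the scatter). The group on this aromatic carbon, para to a large group, therefore matters for inhibition, and of the two groups tried here trifluoromethoxy goes with the lower number. Nothing available explains why the number rises with this change.

Still open, going by these compounds, is whether a different group on the same carbon, such as fluoro, methoxy or trifluoromethyl, would match or improve on the number given by compound 2. On these data alone, it is also open whether the same change would have an effect of this size with a different group elsewhere on the shared core.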